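Changing the Ester Side Group and Cytotoxicity

This account rests on a few compounds, and the source may have more. Where it says the series, first, only, none or still open, it means among the compounds named here.

Measured so far:
compound 1 `CCC(=O)OCCc1c(-c2ccccc2Cl)c2cc(Cl)ccc2[nH]c1=O`: 95000 nM
compound 2 `O=C(CN1C(=O)c2ccccc2C1=O)OCCc1c(-c2ccccc2Cl)c2cc(Cl)ccc2[nH]c1=O`: 960000 nM

In an ADME assay on HepG2 2.2.15 cells (Homo sapiens) for cytotoxicity (on this read-out higher numbers stand for lower toxicity in this test and lower numbers for higher toxicity in this test), compound 2 gives 960000 nM, the highest of the two numbers, with compound 1 giving 95000 nM as the nearest. Compound 3 `O=C(/C=C/c1cccnc1)OCCc1c(-c2ccccc2Cl)c2cc(Cl)ccc2[nH]c1=O` is not yet measured; in it (a group of 8 heavy atoms (7 carbon, 1 nitrogen; one six-membered aromatic ring with 1 hetero atom) in place of a group of 12 heavy atoms (9 carbon, 1 nitrogen, 2 oxygen; one five-membered non-aromatic ring with 1 hetero atom, one six-membered aromatic ring of carbon only), on a carbonyl carbon). Among the compounds with values here, the only measured step, a 10-fold higher number from compound 1 to compound 2 (1.00 log units; beyond the scatter), concerns a different place on the ester chain, so no step bears directly on this change. Because compound 1 gave 95000 nM, a partial return toward that value seems plausible, and compound 3 is therefore expected to show a 3.2-fold lower number from compound 2 to compound 3 (0.51 log units; beyond the scatter), with an estimate of 300000 nM in a range from 60000 nM to 1500000 nM.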

Compound 3, half-maximal cytotoxic concentration: 39000 nM
For compound 3 the middle estimate is 7.7-fold (0.89 log units) above the measured one, and the stated range ends above it.
By their numbers in this assay, from the lowest: compound 3; then compound 1; then compound 2.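

Putting 2-(pyridin-3-yl)ethenyl on the carbonyl carbon gives a 25-fold lower number from compound 2 to compound 3 (1.39 log units; beyond the scatter) in this assay, and in place of ethyl it gives a 2.4-fold lower number from compound 1 to compound 3 (0.39 log units; beyond the scatter). This place on the ester can therefore move the number in both directions, since compound 2 stands highest and compound 3 lowest, the most toxic of the three in this test. Nothing at hand explains these differences. Going by these compounds, whether the ring nitrogen or the double bond matters remains open, and 2-phenylethenyl and 2-(pyridin-3-yl)ethyl would separate the two. How an amine or a carboxylic acid on this chain would read is also unknown.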